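The compounds below may be only part of what the source reports. "The series", "measured", "known", "first", "only" and "open" are said of these compounds alone.

Compound 1 `CCc1nccc2sc(-c3c(C)nc(N[C@H](C)c4ccc(OC(F)(F)F)cc4)nc3N[C@@H]3C[C@H](CO)[C@@H](O)[C@H]3O)nc12` gives 7000 nM in an ADME assay on cells (Homo sapiens) for cytotoxicity, read by polymerase chain reaction, with a stated time of 3 days; a lower number here means that less compound is tolerated, a higher number that more compound is tolerated. Compound 2 `Cc1nc(N[C@H](C)c2ccc(OC(F)(F)F)cc2)nc(N[C@@H]2C[C@H](CO)[C@@H](O)[C@H]2O)c1-c1nc2c(C3CCC3)nccc2s1` gives 5000 nM in this assay. Of the two numbers shown, the one for compound 1 is the larger, yet a 1.4-fold lower number from compound 1 to compound 2 (0.15 log units; within the scatter), so the two compounds cannot be told apart on this basis. Compound 3 `Cc1cc2sc(-c3c(C)nc(N[C@H](C)c4ccc(OC(F)(F)F)cc4)nc3N[C@@H]3C[C@H](CO)[C@@H](O)[C@H]3O)nc2c(C)n1` has not been measured yet. It differs from compound 1 in one place: a group of 11 heavy atoms (8 carbon, 2 nitrogen, 1 sulfur; one five-membered aromatic ring with 2 hetero atoms, one six-membered aromatic ring with 1 hetero atom) in place of a group of 11 heavy atoms (8 carbon, 2 nitrogen, 1 sulfur; one five-membered aromatic ring with 2 hetero atoms, one six-membered aromatic ring with 1 hetero atom), on an aromatic carbon. Within the data shown here, the only measured step also alters this same bicyclic part of the molecule, and that step from compound 1 to compound 2 stayed within the scatter. Among the measured compounds shown here, with only one such comparison, and that one flat, no step beyond the scatter is expected for this rearrangement, in either direction. Compound 3 is therefore expected to give about 6000 nM in this assay, with a plausible range from 2000 nM to 20000 nM, which would mean a 1.2-fold lower number from compound 1 to compound 3 (0.07 log units; within the scatter) as the expected step.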

Compound 3, half-maximal cytotoxic concentration: 20000 nM
Estimate against measurement, compound 3: 3.3-fold (0.52 log units) below; the range from low to high includes it.
By their numbers in this assay, from the lowest: compounds 2 and 1 (each within the scatter of the next); then compound 3.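

In this assay, the step of a 2.9-fold higher number from compound 1 to compound 3 (0.46 log units; beyond the scatter) shows that this bicyclic group can shift the tolerated concentration beyond the scatter, which the change from ethyl to cyclobutyl did not show. The group that leaves and the group that enters have the same counts of heavy atoms, hydrogen-bond donors and hydrogen-bond acceptors, so those counts cannot separate the two compounds, and the change lies only in how the same atoms are joined. Nothing available here accounts for the step.

As far as these compounds go, with a single modest step, it remains open whether other arrangements of these atoms would shift the number as far, or further. From the compounds shown here alone, it is also open what a methoxy group or an amine on the six-membered aromatic ring with 1 hetero atom would do in this assay.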